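A few compounds are considered here, and "the series" means these few. Any claim that something is new, unique, unknown or untested is made for them only; others in the source may bear on it.

- Compound 1 `CCSc1ccc(C2CC(=O)N2c2cc(OC)c(OC)c(OC)c2)cc1`: 204 nM
- Compound 2 `CCOc1ccc(C2C(O)C(=O)N2c2cc(OC)c(OC)c(OC)c2)cc1`: 11 nM
- Compound 3 `COc1cc(N2C(=O)C(O)C2c2ccc(SC)cc2)cc(OC)c1OC`: 15 nM

All three numbers come from a functional assay on HL-60 cells (Homo sapiens) for inhibition, read by resazurin assay, with a stated time of 72 h; on this read-out higher numbers stand for weaker inhibition and lower numbers for stronger inhibition. Compound 2 and compound 3 share the low end of this small set, and compound 1 stands well above both.

The next compound to be measured, compound 4 `CCOc1ccc(C2CC(=O)N2c2cc(OC)c(OC)c(OC)c2)cc1`, is compound 2 with hydrogen in place of hydroxy on a saturated ring carbon.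

Within the data shown here, the one measured step, a 1.4-fold higher number from compound 2 to compound 3 (0.13 log units; within the scatter), is a different change: methylsulfanyl in place of ethoxy on an aromatic carbon. It stays within the scatter. Among the measured compounds shown here, no measured step isolates the loss of the hydroxy group. The closest evidence is compound 1, which also has hydrogen on that ring carbon but carries ethylsulfanyl where compound 2 carries ethoxy. Compound 1 gives 204 nM, while compound 2 gives 11 nM. Taking the small size of a 1.4-fold higher number from compound 2 to compound 3 (0.13 log units; within the scatter) as a guide, compound 4 is expected to land near compound 1 rather than near compound 2.

In this assay, a large step toward a higher number, meaning weaker inhibition, is therefore expected: a 12-fold higher number from compound 2 to compound 4 (1.07 log units; beyond the scatter). The estimated value for compound 4 is 130 nM, with an expected range of 40 nM to 400 nM.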

Compound 4, half-maximal inhibitory concentration: 88 nM
Estimate against measurement, compound 4: 1.5-fold (0.17 log units) above; low and high end bracket the measured number.
By their numbers in this assay, from the lowest: compounds 2 and 3 (each within the scatter of the next); then compound 4; then compound 1.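

In this assay, the hydroxy group on the saturated ring carbon of the four-membered non-aromatic ring now has a step of its own: putting hydrogen in its place gives an 8.0-fold higher number from compound 2 to compound 4 (0.90 log units; beyond the scatter) and so shows that this position affects the read-out. Compound 4 also shows that the group on the aromatic ring still matters without the hydroxy, since ethoxy in place of ethylsulfanyl gives a 2.3-fold lower number from compound 1 to compound 4 (0.37 log units; beyond the scatter) in the same assay. That step is a different swap from methylsulfanyl in place of ethoxy, so the earlier step of a 1.4-fold higher number from compound 2 to compound 3 (0.13 log units; within the scatter) cannot be read as its counterpart, and no measurement here explains either new step.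

The compounds shown leave open whether only the hydroxy group gives the lower number at this ring carbon, or whether a methoxy, an amine or a fluorine there would do the same. They also leave open how the ethylsulfanyl group behaves with the hydroxy group present, and whether a longer chain such as propoxy on the aromatic ring would keep the number of compound 2.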